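The source may report more compounds than this note shows. Statements on the series, on what has been measured and on what is new or still open speak of the compounds shown alone.

Measured compounds in an assay on isolated protein for inhibition of DNA topoisomerase 1 (Homo sapiens), with a stated time of 30 min, tested at 100 uM; a higher number here means a stronger effect of the compound at the concentration tested, a lower number a weaker effect:
compound 1 `Oc1ccc(-c2cc(-c3ccsc3)cc(-c3ccccc3O)n2)cc1` gives 13.8%;
compound 2 `Oc1ccc(-c2cc(-c3ccco3)cc(-c3ccccc3O)n2)cc1` gives 83%;
compound 3 `Oc1cccc(-c2cc(-c3ccoc3)cc(-c3ccccc3O)n2)c1` gives 29.5%.

Compound 3 stands second highest of the three, above compound 1 and well short of compound 2. Among the measured compounds shown here, the only measured step, a number 69.2 percentage points higher from compound 1 to compound 2 (beyond the scatter), concerns furan-2-yl in place of thiophen-3-yl and does not touch the hydroxyphenyl group. Compound 4 `Oc1ccc(-c2cc(-c3ccoc3)cc(-c3ccccc3O)n2)cc1` differs from compound 3 by 4-hydroxyphenyl in place of 3-hydroxyphenyl on an aromatic carbon. For the measured compounds named here, no measured step bears on this change, so the data give no direction for it; the two compounds that carry 4-hydroxyphenyl, compound 1 and compound 2, span a wide range in this assay. Compound 4 is therefore expected near the middle of that range, at 38%, between 12% and 70%. This estimate means an expected step of a number 8.5 percentage points higher from compound 3 to compound 4 (within the scatter), small and uncertain.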

Compound 4, a percentage reported as inhibition, at one concentration (the size of the read-out at that concentration, not a potency): 30.1%
Compound 4: middle estimate off by 7.9 percentage points, on the high side; low and high end bracket the measured number.
By their numbers in this assay, from the lowest: compound 1; then compounds 3 and 4 (each within the scatter of the next); then compound 2.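

In this assay the change from 3-hydroxyphenyl to 4-hydroxyphenyl next to the ring nitrogen gives a number 0.6 percentage points higher from compound 3 to compound 4 (within the scatter) and so does not separate these two compounds. With 4-hydroxyphenyl held fixed, furan-3-yl in place of furan-2-yl gives a number 52.9 percentage points lower from compound 2 to compound 4 (beyond the scatter) while furan-3-yl in place of thiophen-3-yl gives a number 16.3 percentage points higher from compound 1 to compound 4 (beyond the scatter) and thus the high read-out of compound 2 goes with furan-2-yl, not with either furan as such. No evidence on hand accounts for these steps.

As far as these compounds go, whether the hydroxyl position matters alongside furan-2-yl stays open. So does the effect of an amine or a carboxylic acid in place of this hydroxyl.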